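The source may hold more compounds than are shown below. What is called first, only, known or untested is meant among the compounds shown, and "the series" means these compounds.

Compound 1 `COC(=O)C(=O)/C=C(\O)c1ccccc1Cl`: 31%; compound 2 `O=C(O)C(=O)/C=C(\O)c1ccccc1`: 0%.

Among the compounds with values here, in an assay for inhibition of kynurenine 3-monooxygenase (Rattus norvegicus), tested at 10 uM (a lower number here means less inhibition, a higher number more inhibition at the concentration tested (going by the name of the read-out)), compound 2 gives 0%, the lowest of the two numbers measured so far. Compound 1 gives 31%, a gap beyond the usual scatter, yet the two structures differ in more than one place, so only their values can be set side by side. Compound 3 `O=C(O)C(=O)/C=C(\O)c1ccccc1Cl` arises from compound 2 by one change: chloro in place of hydrogen on an aromatic carbon. Within the data shown here, no measured pair shows this change alone. A moderate rise in this assay is expected, because compound 1 gives 31% and also carries chloro. For compound 3 the estimate is 15%, between 0% and 40%, an expected step of a number 15 percentage points higher from compound 2 to compound 3 (beyond the scatter).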

Compound 3, a percentage reported as inhibition, at one concentration (the size of the read-out at that concentration, not a potency): 33%
Compound 3: the middle estimate sits 18 percentage points below what was measured; measured number inside the range.
By their numbers in this assay, from the lowest: compound 2; then compounds 1 and 3 (each within the scatter of the next).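

In this assay, chloro in place of hydrogen on an aromatic carbon, ortho to a group of 8 heavy atoms, gives a number 33 percentage points higher from compound 2 to compound 3 (beyond the scatter) in a single-atom change. With chloro in place, hydrogen in place of methyl on an oxygen next to a carbonyl group gives a number 2 percentage points higher from compound 1 to compound 3 (within the scatter), so the two compounds cannot be told apart here. No measurement given here explains the effect of chloro. From the compounds shown here alone, whether fluoro, bromo or methoxy at this position would match chloro remains open. So does the effect of chloro elsewhere on the ring.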